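A few compounds are considered here, and "the series" means these few. Any claim that something is new, unique, unknown or untested is made for them only; others in the source may bear on it.

In an ADME assay on Vero cells (Chlorocebus sabaeus) for cytotoxicity, read by MTT assay, with a stated time of 72 h (on this read-out lower numbers stand for higher toxicity in this test and higher numbers for lower toxicity in this test), three compounds have been run.
Compound 1 `CC(C)Cc1ccc(C(=O)/C=C/c2ccc(C(=O)O)cc2)cc1` gives the limit < 10 ug/mL.
Compound 2 `COC(=O)c1cc(-c2cccc(NC(=O)c3ccc(/C=C/C(=O)c4ccc(C)c([N+](=O)[O-])c4)cc3)c2)on1` gives the limit > 80 ug/mL.
Compound 3 `CCOC(=O)c1nnn(-c2cccc(NC(=O)c3ccc(/C=C/C(=O)c4ccc(Cl)cc4)cc3)c2)c1C` has no single number; its entry reads "not determined" (no result reported).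

For the measured compounds named here, compound 2 thus stands only at a limit of this assay, and no step between measured compounds that differ in one place is available to lean on. Compound 4 `COC(=O)c1cc(-c2cccc(NC(=O)c3ccc(/C=C/C(=O)c4ccc(OC)c([N+](=O)[O-])c4)cc3)c2)on1` differs from compound 2 in one place: methoxy in place of methyl on an aromatic carbon. Cut one bond further out, the same difference reads 4-methyl-3-nitrophenyl to 4-methoxy-3-nitrophenyl. With nothing measured on such a change, the step of a number no higher from compound 2 to compound 4 (the limit leaves the size open) is expected to stay within the scatter, in no particular direction. Compound 4 is therefore estimated at 80 ug/mL, with a range from 40 ug/mL to 160 ug/mL, and is most likely to be reported again only as a limit.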

Compound 4, half-maximal cytotoxic concentration: > 40 ug/mL
Compound 4: a limit, no number (the forecaster's own chance of this, stated with the estimate: 70%); the middle value lies beyond the limit too.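

For the compounds shown here, compound 2 and compound 4 are both reported only as limits, so no step between them can be read. The compounds shown leave open whether methoxy in place of methyl on an aromatic carbon changes the half-maximal cytotoxic concentration at all.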